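The source may hold more compounds than are shown below. What is called first, only, known or untested is meant among the compounds shown, and "the series" means these compounds.

Three analogues of a shared core have been run in an assay on isolated protein for inhibition of 2-Hydroxyacid oxidase 2 (Homo sapiens), tested at 1 uM; on this read-out higher numbers stand for a stronger effect at the one concentration tested and lower numbers for a weaker effect. Compound 1 `Cc1n[nH]c(C(=O)O)c1Cc1cccc2ccccc12` gives 22%, compound 2 `Cc1n[nH]c(C(=O)O)c1Cc1ccc(Oc2ccccc2)cc1` gives 10% and compound 3 `Cc1n[nH]c(C(=O)O)c1Cc1cccc(-c2ccccc2F)c1` gives 5%. On these numbers compound 2 stands second highest of the three, but its gap to compound 3 lies within the usual scatter, while compound 1 sits beyond the scatter, higher. Compound 4 `Cc1n[nH]c(C(=O)O)c1Cc1ccc(C#N)cc1` is not yet measured; it differs from compound 2 by cyano in place of phenoxy on an aromatic carbon. Going by the values given here, no step between measured compounds is available to anchor the change, so the direction is open, and with all three numbers modest no shift beyond the scatter is expected in either direction. Compound 4 is estimated at 10%, in the range 0% to 25%, a step of no change at the digits printed from compound 2 to compound 4 (within the scatter) expected to remain within the scatter.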

Compound 4, a percentage reported as inhibition, at one concentration (the size of the read-out at that concentration, not a potency): 0%
Estimate against measurement, compound 4: 10 percentage points above, within the range that was stated.
By their numbers in this assay, from the lowest: compounds 4, 3 and 2 (each within the scatter of the next); then compound 1.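

In this assay, going by these compounds alone, cyano in place of phenoxy on an aromatic carbon, para to a large group, gives a number 10 percentage points lower from compound 2 to compound 4 (within the scatter) and is the first step read at this position. The phenoxy ring can therefore give way to the much smaller cyano without a shift beyond the scatter, though both numbers lie too close to separate the two groups. Nothing available accounts for this result.

As far as these compounds go, whether an amine, a carboxylic acid or a longer alkyl chain at this position would move the read-out beyond the scatter remains open. Also open, from the compounds shown here alone, is whether this step would hold on any other substitution pattern of the ring.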